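The source may report more compounds than this note shows. Statements on the series, on what has been measured and on what is new or still open speak of the compounds shown alone.

In a functional assay on the whole organism with Rattus norvegicus as the target (a higher number here means that more compound is needed for the effect, a lower number that less compound is needed), compound 1 `Nc1nc2ccc(OCC(F)(F)F)cc2s1` gives 6.5 mg/kg. As far as these compounds go, for compound 2 `N=c1sc2cc(OC(F)(F)F)ccc2n1CC(=O)O` the same assay reports only a limit, > 10 mg/kg, so where compound 2 stands among the numbers remains open. This is the limit of > 10 mg/kg in this assay, at which 1 of the 2 values shown sits. Compound 3 `C[S+]([O-])Cn1c(=N)sc2cc(OC(F)(F)F)ccc21` differs from compound 2 by a group of 3 heavy atoms (1 carbon, 1 oxygen, 1 sulfur; no ring) in place of a group of 3 heavy atoms (1 carbon, 2 oxygen; no ring), on a saturated chain carbon bound to an aromatic nitrogen. Among the compounds with values here, no measured pair shows what such a change is worth, so the step that the limit leaves unreadable from compound 2 to compound 3 is expected to be small, in no firm direction, and within the usual scatter. Compound 3 is therefore estimated at 12 mg/kg in this assay, with a range from 4 mg/kg to 35 mg/kg.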

Compound 3, dose for half-maximal effect: 2.3 mg/kg
The estimate for compound 3 lay 5.2-fold (0.72 log units) above the measured number, outside the stated range (below it).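

On a saturated chain carbon bound to an aromatic nitrogen, this change matters: replacing carboxy with a group of 3 heavy atoms (1 carbon, 1 oxygen, 1 sulfur) gives an at least 4.3-fold lower number from compound 2 to compound 3 (0.63 log units; beyond the scatter) in this assay. The carboxy group is therefore not needed here for the effect, and less compound suffices without it. Compound 2 carries only a limit, so the full size of the step stays unknown: the limit of > 10 mg/kg in this assay, at which 1 of the 3 values shown sits.

As far as these compounds go, whether an amine or a longer chain in this place would do as well remains open. A single pair also cannot say which atoms of the new group account for the step.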